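Methyl in place of allyloxycarbonyl on sulfur

This account rests on a few compounds, and the source may have more. Where it says the series, first, only, none or still open, it means among the compounds named here.

Among the measured compounds shown here, in a functional assay on HCT-116 cells (Homo sapiens) for inhibition, read by MTT assay, with a stated time of 96 h (a lower number here means a stronger inhibitor of growth, a higher number a weaker inhibitor of growth), compound 1 `C=CCOC(=O)SCCCCCCNC(=O)c1cc(-c2ccncc2)n[nH]1` gives 32900 nM as the only number. Compound 2 `Cc1cc(C(=O)NCCCCCCS)[nH]n1` reads > 50000 nM as a limit of the measurement. Compound 3 `O=C(CCCCCCS)Nc1ccccc1` reads > 50000 nM as a limit too. Compound 4 `CSCCCCCCNC(=O)c1cc(-c2ccncc2)n[nH]1` carries methyl in place of allyloxycarbonyl on a sulfur and has no result yet. For the measured compounds named here, no measured step covers this change. With compound 1 at 32900 nM as the sole reference, a modest loss of growth inhibition is expected. A result reported only as a limit is quite likely for compound 4. The expected step of a 2.1-fold higher number from compound 1 to compound 4 (0.33 log units; beyond the scatter) is small and points towards weaker inhibition. The estimate for compound 4 is 70000 nM with an expected range from 30000 nM to 150000 nM for now.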

Compound 4, concentration for 50% growth inhibition: > 50000 nM
Compound 4 ended at the assay's limit (the forecaster's own chance of this, stated with the estimate: 70%); the middle value lies beyond the limit too.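

In this assay, among the compounds shown here, methyl in place of allyloxycarbonyl on the sulfur gives an at least 1.5-fold higher number from compound 1 to compound 4 (0.18 log units; that floor lies within the scatter) and is the first one-place comparison. The change brings no gain in growth inhibition, though a real loss is not established. The size of the step stays open because the value of compound 4 is a limit: the limit of > 50000 nM in this assay, at which 3 of the 4 values shown sit.

Still open, going by these compounds, is how acetyl or an amine-bearing chain on this sulfur would read against compound 1, and whether either would give a number clear of the limit.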